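This account rests on a few compounds, and the source may have more. Where it says the series, first, only, none or still open, it means among the compounds named here.

For the measured compounds named here, compound 1 `O=C(Nc1ccc(Cl)cn1)C1CCCN(C(=O)c2cc(C(F)(F)F)cc(C(F)(F)F)c2)C1` is one of three compounds so far measured in an ADME assay on PC-3 cells (Homo sapiens) for cytotoxicity, read by WST assay, tested at 100 uM; a lower number here means less inhibition, a higher number more inhibition at the concentration tested (going by the name of the read-out). In this assay compound 1 gives 0%. Compound 2 `Cc1cccc(C(=O)N2CCCC(C(=O)Nc3ccc(Cl)cc3)C2)c1` gives 0% in this assay, and compound 3 `O=C(c1ccccc1)c1cccc(C(=O)N2CCCC(C(=O)Nc3ccc(Cl)cc3)C2)c1` gives 0%. Going by the values given here, the only pair of measured neighbours that differ in one place, no change at the digits printed from compound 2 to compound 3 (within the scatter), shows no movement within the scatter when benzoyl replaces methyl on an aromatic carbon. Compound 1 therefore stands level with compound 2 and compound 3 at the digits shown, with no change beyond the scatter toward either.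

The unmeasured compound 4 `COc1cccc(NC(=O)C2CCCN(C(=O)c3cc(C(F)(F)F)cc(C(F)(F)F)c3)C2)c1` differs from compound 1 in a single place: 3-methoxyphenyl in place of 5-chloropyridin-2-yl on an amide-type nitrogen. Among the compounds with values here, none of the measured steps touches the group on the amide-type nitrogen, so no step bears on this change directly; compound 1 and compound 2, which carry different groups there along with other differences, simply both sit at the same value. Within the data shown here, since every measured compound in this assay sits at the same figure and the one measured step is flat, compound 4 is expected to show no step beyond the scatter, no change at the digits printed from compound 1 to compound 4 (within the scatter). Compound 4 is estimated at 0% in this assay, with a range from -8% to 10%.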

Compound 4, a percentage reported as inhibition, at one concentration (the size of the read-out at that concentration, not a potency): 0%
Compound 4: the middle estimate sits on the measured number at the digits printed; measured number inside the range.
By their numbers in this assay, from the lowest: compounds 1, 2, 3 and 4 (each within the scatter of the next).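

In this assay, for the compounds shown here, the first measured change at this position, where 3-methoxyphenyl replaces 5-chloropyridin-2-yl on an amide-type nitrogen, gives no change at the digits printed from compound 1 to compound 4 (within the scatter). The earlier step, benzoyl in place of methyl, lay on an aromatic carbon and left this nitrogen's substituent untouched, so this result adds a second site at which a single change leaves the reading flat. At this position, the read-out does not separate a six-membered aromatic ring with one hetero atom, carrying chlorine, from a ring of carbon only, carrying methoxy, and no other measurement bears on this flat result.

With all four compounds level, the compounds shown do not reveal whether any group at this position can move the reading, nor do they separate the contributions of the ring nitrogen, the chlorine and the methoxy group. Going by these compounds, it remains open how the reading would respond to an amine or a carboxylic acid on this aromatic ring, or to a longer alkyl chain in place of the ring on the amide-type nitrogen.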